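The source may report more compounds than this note shows. Statements on the series, on what has been measured and on what is new or still open speak of the compounds shown alone.

Compound 1 `O=C(N/N=C/c1ccc([N+](=O)[O-])o1)c1cccs1`: 57200 nM
Compound 2 `CCCCc1ccc(C(=O)N/N=C/c2ccc([N+](=O)[O-])o2)cc1`: 19600 nM
Compound 3 `CCCCCC(=O)N/N=C/c1ccc([N+](=O)[O-])o1`: 19300 nM

All three values come from an ADME assay on U2OS cells (Homo sapiens) for cytotoxicity; on this read-out higher numbers stand for lower toxicity in this test and lower numbers for higher toxicity in this test. Compound 2 and compound 3 lie within the usual scatter of each other, and both numbers are lower than that of compound 1, by a gap beyond the scatter.

Compound 4 `N#Cc1ccc(C(=O)N/N=C/c2ccc([N+](=O)[O-])o2)cc1` has not yet been measured. It differs from compound 2 at one place: cyano in place of butyl on an aromatic carbon.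

Among the measured compounds shown here, no measured step makes this same swap, so the evidence is indirect. The closest guide is a 3.0-fold lower number from compound 1 to compound 3 (0.47 log units; beyond the scatter), a modest step made at a different kind of place. The two compounds carrying a chain, butyl in compound 2 and pentyl in compound 3, share the lower numbers, but three compounds are too few to call this a rule. With the butyl gone, compound 4 is expected to move towards compound 1 at 57200 nM, meaning a higher number and lower toxicity in this assay. The expected change, modest in size, is a 2.1-fold higher number from compound 2 to compound 4 (0.33 log units; beyond the scatter). For compound 4 the estimated value is 42000 nM, with an expected range of 16000 nM to 95000 nM.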

Compound 4, half-maximal cytotoxic concentration: 21400 nM
Compound 4: middle estimate off by 2.0-fold (0.29 log units), on the high side; the measured number falls inside the stated range.
By their numbers in this assay, from the lowest: compounds 3, 2 and 4 (each within the scatter of the next); then compound 1.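

In this assay, putting cyano in place of butyl on an aromatic carbon, para to a large group, gives a 1.1-fold higher number from compound 2 to compound 4 (0.04 log units; within the scatter) and therefore counts as no real change. At this position, then, the read-out stays put when a group of 4 heavy atoms with no hydrogen-bond acceptor gives way to a group of 2 heavy atoms with 1 hydrogen-bond acceptor, and compound 4 goes against the link between a chain and a lower number that compound 2 and compound 3 seemed to suggest. Nothing shown here measures any property that could explain this result.

Going by these compounds, only these two groups have been seen at this position, so it remains open whether the read-out would also hold with quite different groups there, such as an amine, a carboxylic acid or a longer chain. The three compounds that differ at or near this part of the structure also leave open what sets compound 1 apart from the others in this test.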